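Aryl swap on the ring nitrogen of compound 1

The compounds below may be only part of what the source reports. "The series", "measured", "known", "first", "only" and "open" are said of these compounds alone.

Among the measured compounds shown here, compound 1 `CCc1ccc(-n2nc(-c3ccc(C(F)(F)F)cc3O)nc2-c2ccccc2O)cc1` gives 64.4% in a functional assay on PC-12 cells (Rattus norvegicus) for cytotoxicity, read by MTT assay, with stated times of 2 h and 24 h, tested at 1 uM (a lower number here means a weaker effect, a higher number a stronger effect of the compound at the concentration tested), the lower of the two numbers measured so far. Compound 2 `Cc1cc(C)cc(-n2nc(-c3ccc(C(F)(F)F)cc3O)nc2-c2ccccc2O)c1` gives 76.9% in this assay. For the measured compounds named here, the only recorded step, a number 12.5 percentage points higher from compound 1 to compound 2 (beyond the scatter), lies beyond the scatter. Compound 3 `Oc1cc(C(F)(F)F)ccc1-c1nc(-c2ccccc2O)n(-c2cc(F)cc(F)c2)n1` differs from compound 1 by 3,5-difluorophenyl in place of 4-ethylphenyl on an aromatic nitrogen. The entering 3,5-difluorophenyl shares its substitution pattern with the 3,5-dimethylphenyl of compound 2, so a modest rise is expected, a number 6.6 percentage points higher from compound 1 to compound 3 (within the scatter), though fluorine in place of methyl leaves this uncertain. Compound 3 is therefore estimated at 71%, with a range from 56% to 86%.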

Compound 3, a percentage reported as activity, at one concentration (the size of the read-out at that concentration, not a potency): 75.5%
For compound 3 the middle estimate is 4.5 percentage points below the measured one; low and high end bracket the measured number.
By their numbers in this assay, from the lowest: compound 1; then compounds 3 and 2 (each within the scatter of the next).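

In this assay the 3,5-difluorophenyl group gives a number 11.1 percentage points higher from compound 1 to compound 3 (beyond the scatter) and so provides a second replacement of 4-ethylphenyl on the aromatic nitrogen that clears the scatter. Exchanging the 3,5-dimethylphenyl group for 3,5-difluorophenyl gives a number 1.4 percentage points lower from compound 2 to compound 3 (within the scatter), so methyl and fluorine cannot be told apart at this substitution pattern. Nothing available explains these numbers. It remains open whether the substitution pattern shared by 3,5-dimethylphenyl and 3,5-difluorophenyl itself matters, since 4-ethylphenyl is the only other pattern shown. Going by these compounds, how an unsubstituted phenyl or a 3,5-dimethoxyphenyl group would read at this position also remains open.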